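The source may hold more compounds than are shown below. What is called first, only, known or untested is meant among the compounds shown, and "the series" means these compounds.

In an ADME assay on HEp-2 cells (Homo sapiens) for cytotoxicity (a higher number here means that more compound is tolerated, a lower number that less compound is tolerated), compound 1 (`CNCc1ccc2c(c1)nc(Cn1c(=O)n(C(C)C)c3ccccc31)n2CCC(C)C`) gives 1480 nM, compound 2 (`CC(C)CCn1c(Cn2c(=O)n(C(C)C)c3ccccc32)nc2cc(CNS(C)(=O)=O)ccc21`) gives 30800 nM and compound 3 (`CC(C)CCn1c(Cn2c(=O)n(C(C)C)c3ccccc32)nc2cc(CO)ccc21`) gives 31600 nM. Compound 3 thus sits level with compound 2 and far above compound 1. Compound 4 (`C=Cc1ccc2c(c1)nc(Cn1c(=O)n(C(C)C)c3ccccc31)n2CCC(C)C`) carries vinyl in place of hydroxymethyl on an aromatic carbon. The relevant measured steps are a 21-fold higher number from compound 1 to compound 2 (1.32 log units; beyond the scatter) and a 21-fold higher number from compound 1 to compound 3 (1.33 log units; beyond the scatter), both large, and a 1.0-fold higher number from compound 2 to compound 3 (0.01 log units; within the scatter), within the scatter. Vinyl itself is untested in this series, and compound 4 has no methylamino group, so no step beyond the scatter is expected in this assay, with a slight lean downward. The expected change is a 1.8-fold lower number from compound 3 to compound 4 (0.24 log units; within the scatter). For compound 4 the estimate is 18000 nM, with an expected range of 6000 nM to 50000 nM.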

Compound 4, half-maximal cytotoxic concentration: 6520 nM
The estimate for compound 4 lay 2.8-fold (0.44 log units) above the measured number; the range from low to high includes it.
By their numbers in this assay, from the lowest: compound 1; then compound 4; then compounds 2 and 3 (each within the scatter of the next).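

In this assay, vinyl on this aromatic carbon gives an intermediate result, with a 4.8-fold lower number from compound 3 to compound 4 (0.69 log units; beyond the scatter) and a 4.7-fold lower number from compound 2 to compound 4 (0.67 log units; beyond the scatter), yet also a 4.4-fold higher number from compound 1 to compound 4 (0.64 log units; beyond the scatter). Losing the methylamino group is therefore not enough by itself to reach the level of compounds 2 and 3, and the group that enters still matters at this position. Nothing available explains this order. Open, going by these compounds, is whether ethyl would read like vinyl, and whether a carboxylic acid or a primary amine on the same carbon would fall with compound 1 or with compounds 2 and 3.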